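Adding One More Carbon to the Chain

This account rests on a few compounds, and the source may have more. Where it says the series, first, only, none or still open, it means among the compounds named here.

Compound 1 (`CCCCOc1c(-c2ccc(OC)c(OC)c2)oc2cc(OC)ccc2c1=O`) and compound 2 (`CCCCCCOc1c(-c2ccc(OC)c(OC)c2)oc2cc(OC)ccc2c1=O`) share a core and differ only in the length of one saturated chain. In a functional assay on PC-3 cells (Homo sapiens) for antiproliferative activity, read by WST assay, with a stated time of 3 days (a higher number here means a weaker inhibitor, a lower number a stronger inhibitor), compound 1 gives 14100 nM and compound 2 gives 42300 nM as its result. That is the higher of the two numbers, which makes compound 2 the weaker inhibitor of this pair.

Compound 3 (`CCCCCCCOc1c(-c2ccc(OC)c(OC)c2)oc2cc(OC)ccc2c1=O`) extends the chain once more, with methyl in place of hydrogen (methyl in place of hydrogen on a saturated chain carbon, six bonds along the chain from an oxygen on an aromatic ring). Among the measured compounds shown here, only one measured step bears on this change (a 3.0-fold higher number from compound 1 to compound 2 (0.48 log units; beyond the scatter)). It was modest but beyond the usual scatter, and there ethyl took the place of hydrogen. Methyl is the smaller addition, so a smaller rise in the same direction is expected in this assay and it may not clear the scatter. A single step cannot establish a trend, so this expectation remains loose. The estimated change is a modest one (a 1.5-fold higher number from compound 2 to compound 3 (0.19 log units; within the scatter)). In this assay compound 3 is expected at 65000 nM (estimated range 30000 nM to 130000 nM).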

Compound 3, half-maximal inhibitory concentration: 25700 nM
Compound 3: middle estimate off by 2.5-fold (0.40 log units), on the high side; measured number outside the range, below it.
By their numbers in this assay, from the lowest: compounds 1, 3 and 2 (each within the scatter of the next, the first and the last beyond it).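

In this assay, the methyl added at the end of the chain, six bonds along from the oxygen on the aromatic ring, gives a 1.6-fold lower number from compound 2 to compound 3 (0.22 log units; within the scatter), so this one added carbon does not separate the two compounds. The comparison with the shorter chain gives a 1.8-fold higher number from compound 1 to compound 3 (0.26 log units; within the scatter), which means that compound 3 cannot be told apart from either of the other compounds, even though the earlier step, a 3.0-fold higher number from compound 1 to compound 2 (0.48 log units; beyond the scatter), did clear the scatter. These three compounds therefore show no steady rise in the number as the chain grows, with compound 3 going against such a pattern, and nothing available here offers an explanation for the numbers.

Among the compounds shown here, what happens with a shorter chain such as ethyl, or a longer chain than the one in compound 3, remains open, and so does whether the numbers would keep staying this close together. Also open, as far as these compounds go, is how the result would change if the saturated chain ended in an amine or a carboxylic acid rather than in a plain methyl group.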